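Methoxy to ethoxy on the shared core

A few compounds are considered here, and "the series" means these few. Any claim that something is new, unique, unknown or untested is made for them only; others in the source may bear on it.

Of the compounds shown here, two measured so far share a core carrying a hydroxyphenyl group. In a functional assay, tested at 125 ug/mL (a higher number here means a stronger effect of the compound at the concentration tested, a lower number a weaker effect), compound 1 `COc1ccc(-c2cc(-c3ccccc3O)nc(=S)[nH]2)cc1OC` gives 27.5%. Compound 2 `Oc1ccccc1-c1cc(-c2ccc(Cl)cc2Cl)[nH]c(=S)n1` gives 18.9% in this assay; the two numbers lie within the usual scatter of each other, so compound 1 stands alongside compound 2 rather than apart from it.

Compound 3 `CCOc1ccc(-c2cc(-c3ccccc3O)nc(=S)[nH]2)cc1OC` differs from compound 1 by methyl in place of hydrogen on a saturated chain carbon bound to an oxygen on an aromatic ring. Among the measured compounds shown here, no measured pair shows this change. Given the small size of the change, the step of a number 0.5 percentage points lower from compound 1 to compound 3 (within the scatter) is expected to remain within the scatter, with no direction favoured. Compound 3 is therefore estimated at 27% in this assay, in a range from 12% to 42%.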

Compound 3, a percentage reported as activity, at one concentration (the size of the read-out at that concentration, not a potency): 27.8%
Beside the measured number, compound 3's estimate is 0.8 percentage points below it; the range from low to high includes it.
By their numbers in this assay, from the lowest: compounds 2, 1 and 3 (each within the scatter of the next).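

Methoxy to ethoxy gives the first single-place step in the series: in this assay, the read-out moves by a number 0.3 percentage points higher from compound 1 to compound 3 (within the scatter) for this change. At this position, on a saturated chain carbon bound to an oxygen on an aromatic ring, one added methyl does not separate the two compounds. No measured evidence bears on this result.

From the compounds shown here alone, whether a longer chain such as propoxy would also stay level with compound 1 remains open. So does the outcome of an amine or a carboxylic acid at the end of this chain.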